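Bromophenyl shift from compound 2 to compound 3

The source may hold more compounds than are shown below. What is called first, only, known or untested is meant among the compounds shown, and "the series" means these compounds.

In a functional assay on MCF7 cells (Homo sapiens) for cytotoxicity, read by MTT assay, with a stated time of 72 h (a higher number here means a weaker inhibitor, a lower number a stronger inhibitor), compound 1 `COc1cccc(/C=C2\CCC/C(=C\c3ccc(Cl)cc3)C2=O)c1OC` gives 10300 nM and compound 2 `COc1cccc(/C=C2\CCC/C(=C\c3ccccc3Br)C2=O)c1OC` gives 9700 nM, so compound 2 stands level with compound 1 within the scatter. Compound 3 `COc1cccc(/C=C2\CCC/C(=C\c3cccc(Br)c3)C2=O)c1OC` differs from compound 2 as follows: 3-bromophenyl in place of 2-bromophenyl on a double-bonded chain carbon bound to a double-bonded ring carbon. The 3-bromophenyl takes the place of 2-bromophenyl on a double-bonded chain carbon bound to a double-bonded ring carbon. Going by the values given here, one measured step bears on this, a 1.1-fold lower number from compound 1 to compound 2 (0.03 log units; within the scatter), which also exchanges the aryl group at that place. No step beyond the scatter is therefore expected in this assay. The expected change is a 1.0-fold higher number from compound 2 to compound 3 (0.01 log units; within the scatter). For compound 3 the estimated value is 10000 nM, with an expected range of 5000 nM to 20000 nM.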

Compound 3, half-maximal inhibitory concentration: 11700 nM
For compound 3 the middle estimate is 1.2-fold (0.07 log units) below the measured one; measured number inside the range.
By their numbers in this assay, from the lowest: compounds 2, 1 and 3 (each within the scatter of the next).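

In this assay, going by these compounds alone, 3-bromophenyl in place of 2-bromophenyl gives a 1.2-fold higher number from compound 2 to compound 3 (0.08 log units; within the scatter), the first step that keeps the halogen and changes only the name of the bromophenyl group. 3-Bromophenyl in place of 4-chlorophenyl gives a 1.1-fold higher number from compound 1 to compound 3 (0.06 log units; within the scatter), so all three aryl groups on this double-bonded chain carbon read as level. Nothing shown accounts for this flat reading.

Open, as far as these compounds go, is whether an aryl group carrying an amine or a carboxylic acid would step beyond the scatter at this place. The other aryl group of the shared core, with its two methoxy groups, stays constant throughout.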